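Removing the aromatic methoxy: compound 1 to compound 3

The source may hold more compounds than are shown below. What is called first, only, known or untested is meant among the compounds shown, and "the series" means these compounds.

Compound 1 `COc1ccc2occ(CSC(=S)N(C(C)C)C(C)C)c(=O)c2c1` gives 4700 nM in a functional assay on LM7 cells (Homo sapiens) for antiproliferative activity, read by MTT assay, with a stated time of 72 h (a higher number here means a weaker inhibitor, a lower number a stronger inhibitor), and carries the only number shown for the series. Compound 2 `COc1ccc2occ(CSC(=S)N3CCOCC3)c(=O)c2c1` gives > 40000 nM in this assay, which is a limit of the assay and not a number. Among the compounds with values here, the step of an at least 8.5-fold higher number from compound 1 to compound 2 (0.92 log units; beyond the scatter) is the sole measured comparison, and its upper end sits at the limit of > 40000 nM in this assay, at which 1 of the 2 values shown sits. Compound 3 `CC(C)N(C(=S)SCc1coc2ccccc2c1=O)C(C)C` differs from compound 1 by hydrogen in place of methoxy on an aromatic carbon; hydrogen in place of methoxy on an aromatic carbon. Within the data shown here, the measured step concerns the amine on the thiocarbonyl carbon, not the aromatic ring, so none of the measured steps bears on this change. With no guide for this position, the expectation is a step within the scatter, with wide uncertainty. Compound 3 is therefore estimated at 6000 nM, between 2000 nM and 20000 nM, which means an expected step of a 1.3-fold higher number from compound 1 to compound 3 (0.11 log units; within the scatter).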

Compound 3, half-maximal inhibitory concentration: 21900 nM
Estimate against measurement, compound 3: 3.7-fold (0.56 log units) below, outside the stated range (above it).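

Hydrogen in place of methoxy on an aromatic carbon, with diisopropylamino held constant, gives a 4.7-fold higher number from compound 1 to compound 3 (0.67 log units; beyond the scatter). In this assay, the series is therefore sensitive to this aromatic position as well as to the amine on the thiocarbonyl carbon, so the methoxy cannot be treated as a neutral substituent in compound 1. Nothing in the evidence shown bears on what lies behind this step.

On these data alone, it remains open whether the methoxy itself is needed or whether another group on this aromatic carbon, such as ethoxy, hydroxyl or a chlorine atom, would serve equally well. The effect of removing the methoxy alongside morpholin-4-yl also stays unresolved, since compound 2 carries a limit of the assay and not a number.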